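The source may hold more compounds than are shown below. What is called first, only, known or untested is meant among the compounds shown, and "the series" means these compounds.

In a functional assay on NCI-H1299 cells (Homo sapiens) for antiproliferative activity, read by MTT assay, with a stated time of 48 h (on this read-out lower numbers stand for stronger inhibition and higher numbers for weaker inhibition), compound 2, whose structure is `COc1ccc2c(c1)C1(C(=O)N2Cc2ccccc2)C(C#N)=C(N)Oc2cc3oc(-c4ccccc4)cc(=O)c3c(O)c21`, gives > 50000 nM, which is a limit of the assay and not a number. Compound 1, with the structure `CN1C(=O)C2(C(C#N)=C(N)Oc3cc4oc(-c5ccccc5)cc(=O)c4c(O)c32)c2ccccc21`, gives > 50000 nM in this assay, again a limit rather than a measured value. Going by the values given here, compound 2 therefore stands at the same limit as the only other measured compound, and there is the limit of > 50000 nM in this assay, at which 2 of the 2 values shown sit, so no graded step between the two measured compounds can be stated. Compound 3, with the structure `N#CC1=C(N)Oc2cc3oc(-c4ccccc4)cc(=O)c3c(O)c2C12C(=O)N(Cc1ccccc1)c1ccc(Cl)cc12`, has not yet been measured in this assay. Compound 3 differs from compound 2 by chloro in place of methoxy on an aromatic carbon. With both measured compounds at the limit, no step beyond the scatter can be expected in this assay from this change, and compound 3 is most likely to sit at the limit as well. Compound 3 is estimated at 60000 nM in this assay, within the range 20000 nM to 200000 nM, which corresponds to the expected step that the limit leaves unreadable from compound 2 to compound 3.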

Compound 3, half-maximal inhibitory concentration: > 50000 nM
Compound 3 ended at the assay's limit; the forecaster's own chance of this, stated with the estimate: 80%; the middle value is on the limit's open side.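

No step can be read from compound 2 to compound 3, as both values are limits and not numbers: the limit of > 50000 nM in this assay, at which 3 of the 3 values shown sit.

The compounds shown leave open how chloro and methoxy would compare on a compound measured inside the limit, and which change to the shared core would yield such a value.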